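The source may report more compounds than this note shows. Statements on the series, on what has been measured and on what is new or still open speak of the compounds shown alone.

Among the measured compounds shown here, in a functional assay on ECV-304 cells (Homo sapiens), read by MTT assay, with stated times of 24 h and 12 h (on this read-out higher numbers stand for an effect only at larger amounts of compound and lower numbers for an effect already at smaller amounts), compound 1 (`COC(=O)c1ccc(OCc2nc(C)c(C)nc2C)c(OC)c1`) gives 3200000 nM, the higher of the two numbers measured so far. Compound 2 (`Cc1nc(C)c(COc2ccccc2C(=O)O)nc1C`) gives 610000 nM, a lower number, and the gap between the two lies beyond the usual scatter. Compound 3 (`COc1cc(C(=O)O)ccc1OCc1nc(C)c(C)nc1C`) has not yet been measured in this assay. It differs from compound 1 in one small change: hydrogen in place of methyl on an oxygen next to a carbonyl group. This places hydrogen in place of methyl on an oxygen next to a carbonyl group, so methoxycarbonyl becomes carboxy. For the measured compounds named here, no pair of measured compounds shows this change on its own, so there is no direct precedent for its size. Going by the values given here, the only hint comes from compound 2, which also carries a carboxy group and gives 610000 nM, although it differs from compound 1 in more than this one place. A moderate move toward a lower number is therefore expected, probably beyond the scatter, but with real uncertainty. The estimated step is a 3.6-fold lower number from compound 1 to compound 3 (0.55 log units; beyond the scatter). For compound 3 the estimated value is 900000 nM, with an expected range from 200000 nM to 3500000 nM.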

Compound 3, half-maximal effective concentration: 810000 nM
Estimate against measurement, compound 3: 1.1-fold (0.05 log units) above; the range from low to high includes it.
By their numbers in this assay, from the lowest: compounds 2 and 3 (each within the scatter of the next); then compound 1.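

In this assay, replacing methyl with hydrogen on an oxygen next to a carbonyl group, which turns methoxycarbonyl into carboxy, gives a 4.0-fold lower number from compound 1 to compound 3 (0.60 log units; beyond the scatter) in a pair of compounds that differ in this one place only. Compound 2 also carries a carboxy group, but it differs from compound 1 in more than one place, so it could not show what this change does alone; the new pair can, and the step lies beyond the usual scatter of repeated measurements. The information at hand offers no measured explanation for why the number falls with this change.

Going by these compounds, this is still a single pair in a single core, so it remains open whether the same change would give a step of similar size in another compound of the series. The compounds shown also leave open how the assay would read with an amide in place of the carboxy group, or with a longer chain such as ethyl in place of the methyl on that oxygen.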